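Methylsulfonyl for Sulfinyl on a Second Triazole Core

A few compounds are considered here, and "the series" means these few. Any claim that something is new, unique, unknown or untested is made for them only; others in the source may bear on it.

Compound 1 `Cn1c(-c2cccs2)nnc1[S+](C)[O-]`: > 200 mg/kg, a limit.
Compound 2 `Cn1c(-c2cccs2)nnc1S(C)(=O)=O`: > 200 mg/kg, a limit.
Compound 3 `Cn1nc(-c2ccccc2)nc1[S+](C)[O-]`: > 200 mg/kg, a limit.

In a functional assay on the whole organism for antagonist activity, with Mus musculus as the target (a higher number here means that more compound is needed for the effect, a lower number that less compound is needed), compound 1 gives > 200 mg/kg, which is a limit of the assay and not a number. Compound 2 in this assay also gives only the limit > 200 mg/kg. Compound 3 gives only the limit > 200 mg/kg in this assay. The change from compound 1 to compound 2, (a group of 4 heavy atoms (1 carbon, 2 oxygen, 1 sulfur; no ring) in place of a group of 3 heavy atoms (1 carbon, 1 oxygen, 1 sulfur; no ring), on an aromatic carbon), made the step that the two limits leave unreadable from compound 1 to compound 2. Compound 4 `Cn1nc(-c2ccccc2)nc1S(C)(=O)=O` has not yet been measured; it differs from compound 3 by a group of 4 heavy atoms (1 carbon, 2 oxygen, 1 sulfur; no ring) in place of a group of 3 heavy atoms (1 carbon, 1 oxygen, 1 sulfur; no ring), on an aromatic carbon, the same kind of change on a different core. The difference between the two cores is not broken down here. Among the measured compounds shown here, since every value so far sits at the limit of > 200 mg/kg in this assay, at which 3 of the 3 values shown sit, the expected step is a step that the limit leaves unreadable from compound 3 to compound 4. Compound 4 is expected to give 300 mg/kg, most probably again only a limit.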

Compound 4, dose for half-maximal effect: > 200 mg/kg
Compound 4: no number, only a limit; the forecaster's own chance of this, stated with the estimate: 90%; the middle value does not contradict the limit.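

In this assay, among the compounds shown here, compound 3 and compound 4 each give only a limit and not a number, so no step between them can be read. The compounds shown leave open whether methylsulfonyl changes the dose needed on either core, as all values rest on one limit: the limit of > 200 mg/kg in this assay, at which 4 of the 4 values shown sit.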